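The source may hold more compounds than are shown below. What is called first, only, known or untested is meant among the compounds shown, and "the series" means these compounds.

Compound 1 `Nc1nc(N/N=C/c2cncs2)nc2c1ncn2[C@@H]1O[C@H](CO)[C@@H](O)[C@H]1O`: 22 nM
Compound 2 `COc1cc(/C=N/Nc2nc(N)c3ncn([C@@H]4O[C@H](CO)[C@@H](O)[C@H]4O)c3n2)cc(OC)c1OC`: > 10000 nM
Compound 3 `Nc1nc(N/N=C/c2ccc(OCc3ccccc3)c(OCc3ccccc3)c2)nc2c1ncn2[C@@H]1O[C@H](CO)[C@@H](O)[C@H]1O`: > 10000 nM

Within the data shown here, in an assay on CHO-K1 cells for displacement of a labelled ligand from adenosine receptor A1 (Homo sapiens), read by scintillation counting, with a stated time of 60 min (on this read-out lower numbers stand for stronger inhibition and higher numbers for weaker inhibition), compound 1 gives 22 nM, the only number measured here. For compound 2 the assay reports only a limit, > 10000 nM. For compound 3 it likewise reports only a limit, > 10000 nM. Two of the three results are thus (the limit of > 10000 nM in this assay, at which 2 of the 3 values shown sit), and compound 1 stands alone with a measured value, so no ranking among the three can be drawn. Compound 4 `Nc1nc(N/N=C/c2ccc(-n3ccnc3)cc2)nc2c1ncn2[C@@H]1O[C@H](CO)[C@@H](O)[C@H]1O` is not yet measured in this assay. It differs from compound 1 in one place: 4-(1H-imidazol-1-yl)phenyl in place of 1,3-thiazol-5-yl on a carbon with a double bond to nitrogen. The group that enters is larger than the one that leaves and carries a six-membered aromatic ring of carbon only, as do the groups in compound 2 and compound 3. Among the measured compounds shown here, no step between measured compounds is available. For compound 4 a loss in this assay is expected, a step of a 68-fold higher number from compound 1 to compound 4 (1.83 log units; beyond the scatter) beyond the usual scatter. The estimate for compound 4 in this assay is 1500 nM, expected to fall in the range 150 nM to 10000 nM.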

Compound 4, inhibition constant: > 10000 nM
Compound 4 ended at the assay's limit; the forecaster's own chance of this, stated with the estimate: 35%; middle value at least 6.6-fold (0.82 log units) away from the limit.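

Placing 4-(1H-imidazol-1-yl)phenyl instead of 1,3-thiazol-5-yl on the carbon with a double bond to nitrogen gives the first comparison at this position between compounds that differ in one place, and in this assay the change is an at least 450-fold higher number from compound 1 to compound 4 (2.65 log units; beyond the scatter). The result for compound 4 is a limit, so this step is a minimum and not an exact size, and the assay cannot rank the compounds that reach that limit: the limit of > 10000 nM in this assay, at which 3 of the 4 values shown sit. The entering group still carries a five-membered aromatic ring with 2 hetero atoms, so having such a ring is not enough to keep the value of compound 1.

The compounds shown do not reveal which part of the new group accounts for the loss. A plain phenyl group or a 1H-imidazol-5-yl group on the same carbon could help to separate the contributions of the two rings.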